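The compounds below may be only part of what the source reports. "The series", "measured", "known", "first", "only" and "open" are said of these compounds alone.

Compound 1 `COc1ncc(-c2ccc3nccc(-c4ccc(CN5CCCCC5)cc4)c3c2)cc1NS(=O)(=O)c1ccc(F)cc1F` — 32 nM
Compound 2 `COc1ncc(-c2ccc3nccc(-c4ccc(CN5CCN(C)CC5)cc4)c3c2)cc1NS(=O)(=O)c1ccc(F)cc1F` — 336 nM

In a functional assay on U-87MG ATCC cells (Homo sapiens) for cytotoxicity, read by MTT assay, with a stated time of 72 h (a higher number here means a weaker inhibitor, a lower number a stronger inhibitor), compound 1 gives 32 nM and compound 2 gives 336 nM. Among the measured compounds shown here, compound 2 thus holds the higher of the two numbers; the only step known is an 11-fold higher number from compound 1 to compound 2 (1.02 log units; beyond the scatter), which is well beyond the scatter.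

Compound 3 `COc1ncc(-c2ccc3nccc(-c4ccc(CN5CCN(C(C)C)CC5)cc4)c3c2)cc1NS(=O)(=O)c1ccc(F)cc1F` remains to be measured. Against compound 2 the change is isopropyl in place of methyl on an amine nitrogen in a ring. For the measured compounds named here, no measured step touches this position in the same way: the one step known exchanges the whole ring on the saturated chain carbon, whereas the step to compound 3 keeps the piperazine ring and alters only the group on its amine nitrogen. That single step therefore gives no direct guide to the size or direction of the new one. With nothing pointing to a large effect, the expected step is a 1.5-fold lower number from compound 2 to compound 3 (0.18 log units; within the scatter), a modest change that may not exceed the scatter, with a slight lean toward a lower number. For compound 3 the estimate in this assay is 220 nM, with a range from 60 nM to 800 nM.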

Compound 3, half-maximal inhibitory concentration: 468 nM
Estimate against measurement, compound 3: 2.1-fold (0.33 log units) below; the range from low to high includes it.
By their numbers in this assay, from the lowest: compound 1; then compounds 2 and 3 (each within the scatter of the next).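

In this assay, isopropyl in place of methyl on the amine nitrogen of the piperazine ring gives a 1.4-fold higher number from compound 2 to compound 3 (0.14 log units; within the scatter), so this position tolerates the larger of these two alkyl groups without a change that can be told from the scatter, something the earlier ring exchange could not show. The large separation from the piperidine of compound 1 persists with either group on that nitrogen, as an 11-fold higher number from compound 1 to compound 2 (1.02 log units; beyond the scatter) and a 15-fold higher number from compound 1 to compound 3 (1.17 log units; beyond the scatter) both show, so in these three compounds the substituent exchange does not recover the number of compound 1. No measurement available here bears on the reason for either result.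

The compounds shown leave open whether this tolerance extends beyond small alkyl groups, for example to a hydrogen on the same nitrogen, an acetyl group or a longer chain ending in a hydroxyl group. They also leave open whether another ring on the saturated chain carbon, such as morpholine or pyrrolidine, would stand nearer to compound 1 or to the two piperazines.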